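The compounds below may be only part of what the source reports. "The series", "measured", "known", "first", "only" and "open" are said of these compounds alone.

Compound 1 `Cc1ccc(-c2c(C)c(-c3ccc(C)c(C)c3)c(C(OC(C)(C)C)C(=O)O)c(C)c2N)cc1C` is one of three measured compounds in an ADME assay on MT4 cells (Homo sapiens) for cytotoxicity, read by MTT assay, with a stated time of 4 days (on this read-out lower numbers stand for higher toxicity in this test and higher numbers for lower toxicity in this test), where compound 1 gives 12000 nM. Compound 2 `Cc1ccc(-c2c(C)c(-c3ccc(C)c(C)c3)c(C(OC(C)(C)C)C(=O)O)c(C)c2NS(=O)(=O)c2ccccc2)cc1C` gives 11000 nM, and compound 3 `CCNC(=O)Nc1c(C)c(C(OC(C)(C)C)C(=O)O)c(-c2ccc(C)c(C)c2)c(C)c1-c1ccc(C)c(C)c1` gives 15000 nM. On these numbers compound 1 stands second highest of the three, with every value within the scatter of the others. Compound 4 `Cc1ccc(-c2c(C)c(-c3ccc(C)c(C)c3)c(C(OC(C)(C)C)C(=O)O)c(C)c2NC(=O)c2ccccc2)cc1C` differs from compound 1 by benzoyl in place of hydrogen on a nitrogen on an aromatic ring. Two measured steps alter the same nitrogen on an aromatic ring: a 1.1-fold lower number from compound 1 to compound 2 (0.04 log units; within the scatter) and a 1.3-fold higher number from compound 1 to compound 3 (0.10 log units; within the scatter). Both stay within the scatter, so a third group at that position is expected to give no step beyond the scatter in this assay. The step from compound 1 to compound 4 is therefore expected to be no change at the digits printed from compound 1 to compound 4 (within the scatter). Compound 4 is estimated at 12000 nM, between 7000 nM and 21000 nM.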

Compound 4, half-maximal cytotoxic concentration: 9100 nM
Compound 4: the middle estimate sits 1.3-fold (0.12 log units) above what was measured, within the range that was stated.
By their numbers in this assay, from the lowest: compounds 4, 2, 1 and 3 (each within the scatter of the next).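

The aromatic benzoyl group also leaves this nitrogen within the scatter in this assay (a 1.3-fold lower number from compound 1 to compound 4 (0.12 log units; within the scatter)). Compound 4 also stays within the scatter of the two other substituted compounds (a 1.6-fold lower number from compound 3 to compound 4 (0.22 log units; within the scatter); a 1.2-fold lower number from compound 2 to compound 4 (0.08 log units; within the scatter)), so benzoyl, phenylsulfonyl and ethylcarbamoyl cannot be told apart at this position in this test. No supporting measurement is available to explain this. Still open, going by these compounds, is whether a chain ending in an amine or a carboxylic acid on this nitrogen would also stay within the scatter.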